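The compounds below may be only part of what the source reports. "The series", "measured", "known", "first", "only" and "open" are said of these compounds alone.

Measured in an ADME assay on a cell-free system (plasma, Homo sapiens) for metabolic stability, read by LC-MS; a higher number here means that the compound lasts longer, a lower number that the compound disappears faster:
- Compound 1 `NCc1ccc(C(=O)Nc2ccncc2)cc1-c1cccc(C(=O)OCC2CCCCC2)c1`: 1.65 h
- Compound 2 `NCc1ccc(C(=O)Nc2ccncc2)cc1-c1cccc(C(=O)OCc2ccccc2)c1`: 1.07 h
- Compound 3 `CC(C)OCCOC(=O)c1cccc(-c2cc(C(=O)Nc3ccncc3F)ccc2CN)c1`: 0.1 h

Compound 3 stands lowest of the three, well under compound 2 and compound 1. Compound 4 `NCc1ccc(C(=O)Nc2ccncc2F)cc1-c1cccc(C(=O)O)c1` differs from it in one place: hydrogen in place of 2-isopropoxyethyl on an oxygen next to a carbonyl group. In words, hydrogen takes the place of 2-isopropoxyethyl on an oxygen next to a carbonyl group, so (2-isopropoxyethoxy)carbonyl becomes carboxy.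

Within the data shown here, the only measured step is a 1.5-fold lower number from compound 1 to compound 2 (0.19 log units; within the scatter). Among the measured compounds shown here, it exchanges cyclohexyl for phenyl, and no measured compound has hydrogen on that oxygen, so it offers little guidance on size. Losing the whole chain is a larger change, and compound 3 at 0.1 h leaves ample room upward. The expected change in this assay is a rise well beyond the scatter, a 150-fold higher number from compound 3 to compound 4 (2.18 log units; beyond the scatter). For compound 4 the estimated half-life is 15 h, within an expected range of 4 h to 60 h.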

Compound 4, half-life: > 2 h
Compound 4 was reported as a limit; the forecaster's own chance of this, stated with the estimate: 50%; the middle value is on the limit's open side.
By their numbers in this assay, from the lowest: compound 3; then compounds 2 and 1 (each within the scatter of the next). At a limit, above all of these: compound 4.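

At this oxygen next to a carbonyl group, swapping 2-isopropoxyethyl for hydrogen gives an at least 20-fold higher number from compound 3 to compound 4 (1.30 log units; beyond the scatter) in this assay, so (2-isopropoxyethoxy)carbonyl becoming carboxy is a large change. The earlier step, phenyl for cyclohexyl, stayed within the scatter, whereas this one, which removes the whole chain, lies beyond it. The reading for compound 4 is a limit, not a number: the limit of > 2 h in this assay, at which 1 of the 4 values shown sits.

From the compounds shown here alone, how far compound 4 lies past that limit stays open. So does the outcome with a methyl group on this oxygen, or with an amide in place of carboxy.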